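Compound 3: a furan-3-yl group on the shared core

The compounds below may be only part of what the source reports. "The series", "measured", "known", "first", "only" and "open" are said of these compounds alone.

In a functional assay on A549 cells (Homo sapiens) for antiproliferative activity, read by XTT assay, with a stated time of 72 h (on this read-out higher numbers stand for weaker inhibition and lower numbers for stronger inhibition), compound 1 (`C=C(C)CCC[C@]1(C)C2=CCC[C@](C)(C[C@@H](OC(C)=O)C3=CC(=O)OC3O)[C@H]2CC[C@H]1C`) gives 3200 nM and compound 2 (`C=C(C)CCC[C@]1(C)C2=CCC[C@](C)(C[C@@H](O)C3=CC(=O)OC3O)[C@H]2CC[C@H]1C`) gives 3800 nM in the same assay. For the measured compounds named here, compound 2 therefore stands level with the only other measured compound, the two values lying within the scatter (a 1.2-fold higher number from compound 1 to compound 2 (0.07 log units; within the scatter)). Compound 3 (`C=C(C)CCC[C@]1(C)C2=CCC[C@](C)(C[C@@H](O)c3ccoc3)[C@H]2CC[C@H]1C`) differs from compound 2 by one change (a group of 5 heavy atoms (4 carbon, 1 oxygen; one five-membered aromatic ring with 1 hetero atom) in place of a group of 7 heavy atoms (4 carbon, 3 oxygen; one five-membered non-aromatic ring with 1 hetero atom), on a saturated chain carbon bound to an oxygen on a saturated carbon and a saturated chain carbon). That measured step exchanges acetyl for hydrogen on an oxygen and leaves the departing group untouched, so it says nothing direct about this change. Going by the values given here, no measured compound carries furan-3-yl, and both carry the group that leaves. A higher number, meaning weaker inhibition, is the tentatively expected direction, and the expected step is a 2.9-fold higher number from compound 2 to compound 3 (0.46 log units; beyond the scatter) on this thin evidence. In this assay the estimated value of compound 3 is 11000 nM within an expected range of 3500 nM to 40000 nM overall.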

Compound 3, half-maximal inhibitory concentration: 66000 nM
Estimate against measurement, compound 3: 6.0-fold (0.78 log units) below, and the stated range ends below it.
By their numbers in this assay, from the lowest: compounds 1 and 2 (each within the scatter of the next); then compound 3.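

Working notes: at the saturated chain carbon bound to an oxygen on a saturated carbon and a saturated chain carbon, furan-3-yl in place of the non-aromatic five-membered ring group gives in this assay a 17-fold higher number from compound 2 to compound 3 (1.24 log units; beyond the scatter) and this is a large step. For the compounds shown here, the acetyl exchange on the oxygen between compound 1 and compound 2 stayed within the scatter, so this ring group is the first place where a change moves the read-out clearly. Going by these compounds alone, the single step swaps the whole group, with 3 hydrogen-bond acceptors and 1 donor leaving and 1 acceptor and no donor entering, so no one feature of it can be singled out, and no evidence on the cause is at hand.

Still open, going by these compounds, is how a carboxylic acid or an amine on this chain carbon would read. Also open, on these data alone, is whether an acetyl on the oxygen would stay as silent with furan-3-yl in place.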